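This account rests on a few compounds, and the source may have more. Where it says the series, first, only, none or still open, it means among the compounds named here.

Measured in a functional assay on SK-OV-3 cells (Homo sapiens) for antiproliferative activity, read by MTT assay, with a stated time of 72 h; on this read-out higher numbers stand for weaker inhibition and lower numbers for stronger inhibition:
- compound 1 `COc1cc(OC)cc(-c2cccc(NC(=O)CCc3cccc4c3B(O)OC4)c2)c1`: 44 nM
- compound 2 `COc1cc(OC)cc(-c2cccc(NC(=O)CCc3ccc4c(c3)B(O)OC4)c2)c1`: 29000 nM
- compound 3 `COc1cccc(-c2cccc(NC(=O)CCc3ccc4c(c3)COB4O)c2)c1`: > 100000 nM (a limit, not a number)

Compound 3 has no true number, only a limit: the limit of > 100000 nM in this assay, at which 1 of the 3 values shown sits.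

Compound 4 `COc1cc(OC)cc(-c2cccc(NC(=O)CCc3ccc4c(c3)COB4O)c2)c1` keeps the core of compound 3 and changes 3-methoxyphenyl to 3,5-dimethoxyphenyl, with methoxy in place of hydrogen on an aromatic carbon.

Within the data shown here, no measured step makes this change directly. Compound 1 and compound 2 already carry 3,5-dimethoxyphenyl, but their cores differ from that of compound 4. Among the measured compounds shown here, the one measured step, a 660-fold higher number from compound 1 to compound 2 (2.82 log units; beyond the scatter), shows that the group on the chain can matter greatly. It also shows that 3,5-dimethoxyphenyl alone does not ensure strong inhibition, as compound 2 gives only 29000 nM.

A modest gain is therefore expected, and a second limit reading remains possible. The expected change is an at least 2.5-fold lower number from compound 3 to compound 4 (0.39 log units; beyond the scatter), toward stronger inhibition. For compound 4 the estimate is 40000 nM, with an expected range of 6000 nM to 100000 nM.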

Compound 4, half-maximal inhibitory concentration: 93000 nM
Compound 4: middle estimate off by 2.3-fold (0.37 log units), on the low side; measured number inside the range.
By their numbers in this assay, from the lowest: compound 1; then compound 2; then compound 4. At a limit, above all of these: compound 3.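

In this assay, methoxy in place of hydrogen on an aromatic carbon gives an at least 1.0-fold lower number from compound 3 to compound 4 (0.03 log units; that floor lies within the scatter), so no gain from this change can be claimed on this core. Compound 3 has only a limit, not a number: the limit of > 100000 nM in this assay, at which 1 of the 4 values shown sits.

With 3,5-dimethoxyphenyl kept, changing the group on the chain gives a 3.2-fold higher number from compound 2 to compound 4 (0.51 log units; beyond the scatter) and a 2100-fold higher number from compound 1 to compound 4 (3.33 log units; beyond the scatter), so the group on the chain separates these compounds clearly, and one arrangement stands far from the other two.

On these data alone, whether the same methoxy change would matter on the core of compound 1 stays open, since that core appears here only with 3,5-dimethoxyphenyl. Also open, as far as these compounds go, is how an amine or a carboxylic acid in place of methoxy on this ring, or a longer chain before the amide, would read.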